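The source may report more compounds than this note shows. Statements on the series, on what has been measured and on what is new or still open speak of the compounds shown alone.

In a functional assay for inhibition, with Homo sapiens as the target (on this read-out lower numbers stand for stronger inhibition and higher numbers for weaker inhibition), the measured compounds read:

Compound 1 `COc1ccccc1C(=O)/C=C/c1ccccc1`: 2230 nM
Compound 2 `COC(=O)c1ccccc1C(=O)/C=C/c1ccccc1`: 1950 nM
Compound 3 `CN(C)C(=O)c1ccccc1C(=O)/C=C/c1ccccc1`: 5500 nM

Compound 3 has the highest number of the three. Compound 4 `CN(C)c1ccccc1C(=O)/C=C/c1ccccc1` differs from it in one place, with dimethylamino in place of dimethylcarbamoyl on an aromatic carbon. Two measured steps introduce the leaving group: a 2.5-fold higher number from compound 1 to compound 3 (0.39 log units; beyond the scatter), and a 2.8-fold higher number from compound 2 to compound 3 (0.45 log units; beyond the scatter). A third, a 1.1-fold lower number from compound 1 to compound 2 (0.06 log units; within the scatter), compares the two groups it replaced. None of them tests dimethylamino on the aromatic carbon, so the evidence is indirect. A modest move toward a lower number is therefore expected in this assay. The expected step is a 1.8-fold lower number from compound 3 to compound 4 (0.26 log units; within the scatter). Compound 4 is estimated at 3000 nM, with an expected range of 1000 nM to 8000 nM.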

Compound 4, half-maximal inhibitory concentration: 1770 nM
Estimate against measurement, compound 4: 1.7-fold (0.23 log units) above; low and high end bracket the measured number.
By their numbers in this assay, from the lowest: compounds 4, 2 and 1 (each within the scatter of the next); then compound 3.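

In this assay, the dimethylcarbamoyl group of compound 3 now stands apart from all three other groups at this aromatic carbon, since dimethylamino in its place gives a 3.1-fold lower number from compound 3 to compound 4 (0.49 log units; beyond the scatter). Dimethylamino cannot be told apart from the remaining two groups, with a 1.1-fold lower number from compound 2 to compound 4 (0.04 log units; within the scatter) and a 1.3-fold lower number from compound 1 to compound 4 (0.10 log units; within the scatter). No measurement shown here accounts for the separate standing of the dimethylcarbamoyl compound. The compounds shown leave open how a primary amine or a carboxylic acid at this aromatic carbon would compare. They also leave open whether any group there can reach a number clearly lower than these three.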